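The source may report more compounds than this note shows. Statements on the series, on what has been measured and on what is new or still open speak of the compounds shown alone.

Measured set:
compound 1 `COc1cc(OC)c2c(=O)cc(-c3ccc(OC4CCN(C)CC4)cc3)oc2c1` — "not determined" (no result reported)
compound 2 `COc1cc(OC)c2c(=O)cc(-c3ccc(OCCN)cc3)oc2c1` — 70%
compound 3 `COc1cc(OC)c2c(=O)cc(-c3ccc(OCCCN)cc3)oc2c1` — "not determined" (no result reported)

In a functional assay (Homo sapiens) for antiproliferative activity, read by resazurin assay, with a stated time of 48 h, tested at 20 uM (on this read-out higher numbers stand for a stronger effect at the one concentration tested and lower numbers for a weaker effect), compound 1 has no number, and compound 3 likewise has none; only compound 2 gives a figure, 70% in this assay. For the measured compounds named here, compound 1 therefore stands without a value, and no step between measured compounds can be drawn from it.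

Compound 4 `COc1cc(OC)c2c(=O)cc(-c3ccc(OCC(O)CN4CCCC4)cc3)oc2c1` is reached from compound 1 by 2-hydroxy-3-(pyrrolidin-1-yl)propyl in place of 1-methylpiperidin-4-yl on an oxygen on an aromatic ring. Going by the values given here, no measured pair carries this change, and compound 1 itself is blank, so neither size nor direction of the step in this assay can be fixed from what is in hand; nothing beyond the scatter is assumed. The only anchor in this assay is compound 2 with 70%. On that anchor compound 4 is expected to give about 65% in this assay, with a range from 40% to 90%.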

Compound 4, a percentage reported as inhibition, at one concentration (the size of the read-out at that concentration, not a potency): 57%
Compound 4: middle estimate off by 8 percentage points, on the high side, and the stated range covers the measured number.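

For the compounds shown here, the change from the aminoethyl chain to 2-hydroxy-3-(pyrrolidin-1-yl)propyl gives a number 13 percentage points lower from compound 2 to compound 4 (beyond the scatter) in this assay and is the first readable step on this oxygen on an aromatic ring, so the position still carries a clear read-out with a ring-bearing chain. Steps to compound 1 and compound 3 cannot be read, as both lack a number. No supporting data bear on the origin of this step.

The change alters the chain, hydroxyl and amine together, leaving their shares open. A 3-(pyrrolidin-1-yl)propyl chain without the hydroxyl, or a piperidine or morpholine ring in place of pyrrolidine, would separate them.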